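A few compounds are considered here, and "the series" means these few. Any claim that something is new, unique, unknown or untested is made for them only; others in the source may bear on it.

Measured so far in an ADME assay on WI-38 cells (Homo sapiens) for cytotoxicity, read by MTT assay, with a stated time of 72 h; a higher number here means a weaker inhibitor, a lower number a stronger inhibitor:
Compound 1, `O=C(CCc1cccc2c1B(O)OC2)Nc1nccs1`, gives > 100000 nM, which is a limit of the assay rather than a number.
Compound 2, `CC(C)(C)c1ccc(NC(=O)CCc2cccc3c2B(O)OC3)cc1`, gives 55000 nM.
Compound 3, `O=C(CCc1cccc2c1B(O)OC2)Nc1cccc(-c2cccc(F)c2)c1`, gives 37000 nM.

Compound 3 thus has the lowest of the two numbers in this assay, but compound 2 lies within the usual scatter of it, so the two cannot be separated on these data. Compound 1 sits at the limit of > 100000 nM in this assay, at which 1 of the 3 values shown sits, which is a limit and not a number.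

The next compound, compound 4, `O=C(CCc1cccc2c1B(O)OC2)Nc1cccc(-c2ccc(C(F)(F)F)cc2)c1`, differs from compound 3 in a single place:
4-(trifluoromethyl)phenyl in place of 3-fluorophenyl on an aromatic carbon
Going by the values given here, no measured pair of compounds differs in this way, so there is no direct precedent for the size of this step. Both measured numbers are weak and close together, and the change keeps a six-membered aromatic ring of carbon only in the same place, so the expected step from compound 3 to compound 4 in this assay is a 1.2-fold lower number from compound 3 to compound 4 (0.09 log units; within the scatter), no larger than the scatter. On that basis compound 4 is estimated to give about 30000 nM in this assay, with a likely range from 10000 nM to 100000 nM.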

Compound 4, half-maximal inhibitory concentration: 26000 nM
The estimate for compound 4 lay 1.2-fold (0.06 log units) above the measured number; measured number inside the range.
By their numbers in this assay, from the lowest: compounds 4, 3 and 2 (each within the scatter of the next, the first and the last beyond it). At a limit, above all of these: compound 1.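

Going by these compounds alone, the first comparison between compounds that differ in one place is a 1.4-fold lower number from compound 3 to compound 4 (0.15 log units; within the scatter) in this assay, for 4-(trifluoromethyl)phenyl in place of 3-fluorophenyl on an aromatic carbon. At this place, then, one fluorine-bearing phenyl ring can be exchanged for a larger one with no difference that can be told from the scatter. Nothing measured here speaks to why the step has this size.

From the compounds shown here alone, both groups in this step are aromatic rings of carbon only that carry fluorine, so it remains open whether a different kind of group at this place, such as an amine or a carboxylic acid, would move the number beyond the scatter. A single step also leaves open what a longer chain between the amide and the shared core would do.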